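The source may report more compounds than this note shows. Statements on the series, on what has been measured and on what is new or still open speak of the compounds shown alone.

Compound 1 `Cc1n[nH]c(C(=O)O)c1Cc1cccc(-c2ccc(C#N)cc2)c1`: 46%
Compound 2 `Cc1n[nH]c(C(=O)O)c1Cc1cccc(-c2ccccc2F)c1`: 22%
Compound 3 `Cc1n[nH]c(C(=O)O)c1Cc1cccc(C#N)c1`: 19%

These three numbers come from an assay on isolated protein for inhibition of 2-Hydroxyacid oxidase 2 (Homo sapiens), tested at 10 uM; on this read-out higher numbers stand for a stronger effect at the one concentration tested and lower numbers for a weaker effect. Compound 3 gives the smallest of them, though the value of compound 2 lies within the scatter of it; compound 1 stands clearly apart, as a number 27 percentage points lower from compound 1 to compound 3 (beyond the scatter) shows. Compound 4 `Cc1n[nH]c(C(=O)O)c1Cc1cccc(OC(F)(F)F)c1` differs from compound 3 in one place: trifluoromethoxy in place of cyano on an aromatic carbon. Among the measured compounds shown here, two measured steps bear on this position. The step of a number 27 percentage points lower from compound 1 to compound 3 (beyond the scatter) was modest, while a number 3 percentage points lower from compound 2 to compound 3 (within the scatter) stayed within the scatter. For the measured compounds named here, no measured compound carries a trifluoromethoxy group, so the new change has no direct precedent. A small step is expected, with much uncertainty: a number 6 percentage points higher from compound 3 to compound 4 (within the scatter). Compound 4 is therefore estimated at 25%, in a range from 8% to 42%.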

Compound 4, a percentage reported as inhibition, at one concentration (the size of the read-out at that concentration, not a potency): 26%
For compound 4 the middle estimate is 1 percentage points below the measured one; the range from low to high includes it.
By their numbers in this assay, from the lowest: compounds 3, 2 and 4 (each within the scatter of the next); then compound 1.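

Trifluoromethoxy in place of cyano gives a number 7 percentage points higher from compound 3 to compound 4 (within the scatter), and in place of 2-fluorophenyl it gives a number 4 percentage points higher from compound 2 to compound 4 (within the scatter), so at this position in this assay these three groups cannot be told apart. Trifluoromethoxy in place of 4-cyanophenyl gives a number 20 percentage points lower from compound 1 to compound 4 (beyond the scatter), which leaves 4-cyanophenyl as the only one of the four groups that stands apart here. Nothing measured explains these results. Going by these compounds, whether an unsubstituted phenyl would stand with compound 1 or with the other three remains open, which leaves the role of the cyano on the outer ring unsettled. An amine at this position is equally untested here.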